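A thiophene for a pyridine side chain in the same core

The source may hold more compounds than are shown below. What is called first, only, known or untested is meant among the compounds shown, and "the series" means these compounds.

Going by the values given here, compound 1 `Cc1cc(NCCCc2ccccn2)n2nc(C)c(-c3ccccc3)c2n1` is one of two compounds measured in a physicochemical assay for solubility, read by HPLC, using the shake flask method, measured as kinetic solubility, with a stated time of 2 h, at pH 7.4; a higher number here means a more soluble compound, a lower number a less soluble compound. In this assay compound 1 gives 5900 nM, the lower of the two numbers available, while compound 2 `Cc1cc(N(C)Cc2ccccn2)n2nc(C)c(-c3ccccc3)c2n1` gives 17500 nM, a higher number that lies beyond the usual scatter. Among the compounds with values here, no single-point step between these two has been worked out, so their values stand on their own.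

Compound 3 `Cc1cc(NCc2cccs2)n2nc(C)c(-c3ccccc3)c2n1` has not yet been measured. Relative to compound 1 it carries one change: thiophen-2-yl in place of 2-(pyridin-2-yl)ethyl on a saturated chain carbon bound to a nitrogen on an aromatic ring. The group that leaves holds a six-membered aromatic ring with one hetero atom on a longer chain; the group that enters is a five-membered aromatic ring with one hetero atom on a shorter chain, both counted with one hydrogen-bond acceptor and no charge.

Within the data shown here, with no measured step of this kind to lean on, the expectation is drawn from the change itself. Compound 3 is expected to sit somewhat below compound 1, with the step of a 2.0-fold lower number from compound 1 to compound 3 (0.29 log units; within the scatter) estimated to fall at or just beyond the scatter. For compound 3 the estimated value is 3000 nM, with a range from 800 nM to 12000 nM.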

Compound 3, solubility: < 5000 nM
Compound 3 was reported as a limit; the forecaster's own chance of this, stated with the estimate: 10%; the middle value does not contradict the limit.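

In this assay compound 3 is reported as a limit, < 5000 nM, and not as a number. Going by these compounds alone, this gives the first step at this place on the shared core, an at least 1.1-fold lower number from compound 1 to compound 3 (0.07 log units; that floor lies within the scatter), for the exchange of 2-(pyridin-2-yl)ethyl for thiophen-2-yl on a saturated chain carbon bound to a nitrogen on an aromatic ring, and it fixes only a floor for that exchange, not a size. As far as these compounds go, the true size of the step stays unknown because compound 3 rests on a limit: the limit of < 5000 nM in this assay, at which 1 of the 3 values shown sits.

The same difference, cut one bond further out, reads 3-(pyridin-2-yl)propyl to (thiophen-2-yl)methyl, so the ring and the chain length change together, and the compounds shown cannot tell the two apart; a 3-(thiophen-2-yl)propyl group on the same nitrogen would hold the chain and change only the ring, while a (pyridin-2-yl)methyl group would hold the ring and change only the chain. Also open, from the compounds shown here alone, is how this side chain would read in this assay if it carried an amine or a carboxylic acid.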